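A few compounds are considered here, and "the series" means these few. Any claim that something is new, unique, unknown or untested is made for them only; others in the source may bear on it.

Measured compounds:
- compound 1 `O=C(NCc1cn(Cc2ccc(F)cc2)nn1)c1cn(-c2ccccc2)nc1-c1ccccc1`: 7000 nM
- compound 2 `COc1ccc(-c2nn(-c3ccccc3)cc2C(=O)NCc2cn(Cc3ccc(F)cc3)nn2)cc1`: 460 nM

The two measured compounds share a core and differ in a single place. In a functional assay on MCF7 cells (Homo sapiens) for antiproliferative activity, read by sulforhodamine B assay, with a stated time of 48 h (on this read-out higher numbers stand for weaker inhibition of growth and lower numbers for stronger inhibition of growth), compound 1 gives 7000 nM, whereas compound 2 gives 460 nM. The step of a 15-fold lower number from compound 1 to compound 2 (1.18 log units; beyond the scatter) goes with a methoxy in place of hydrogen on an aromatic carbon. Among the measured compounds shown here, compound 2 therefore holds the lower of the two numbers, with compound 1 as its only neighbour.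

Compound 3 `COc1ccc(-c2nn(-c3ccccc3)cc2C(=O)NCc2cn(Cc3ccc(OC)c(OC)c3)nn2)cc1` is not yet measured. It differs from compound 2 by 3,4-dimethoxyphenyl in place of 4-fluorophenyl on a saturated chain carbon bound to an aromatic nitrogen. For the measured compounds named here, the single measured step, from compound 1 to compound 2, concerns a different part of the molecule, so nothing measured so far bears directly on this change. Going by the values given here, with no step to lean on, the expectation for compound 3 rests on compound 2 alone, and the step of a 1.1-fold higher number from compound 2 to compound 3 (0.04 log units; within the scatter) is expected to stay within the scatter. From the compounds shown here alone, compound 3 is accordingly estimated at 500 nM, within a range from 150 nM to 1700 nM, the width reflecting that this position is untested.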

Compound 3, concentration for 50% growth inhibition: > 100000 nM
Compound 3: no number, only a limit; the forecaster's own chance of this, stated with the estimate: 3%; middle value at least 200-fold (2.30 log units) from the limit.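

In this assay compound 3 gives > 100000 nM, which is a limit of the assay and not a number: the limit of > 100000 nM in this assay, at which 1 of the 3 values shown sits.

Among the compounds shown here, the change from 4-fluorobenzyl to 3,4-dimethoxybenzyl goes with an at least 210-fold higher number from compound 2 to compound 3 (2.33 log units; beyond the scatter), which shows that this position, on a saturated chain carbon bound to an aromatic nitrogen and left unchanged between the earlier compounds, strongly affects the read-out. The earlier step, a 15-fold lower number from compound 1 to compound 2 (1.18 log units; beyond the scatter), went with methoxy in place of hydrogen on an aromatic carbon, so the favourable result seen with methoxy there does not carry over to a ring bearing two methoxy groups at this other position.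

The compounds shown leave open whether the loss comes from removing the fluorine, from adding the methoxy groups, or from the two together, as all of these occur in the single change from compound 2 to compound 3. An unsubstituted benzyl, a benzyl carrying one methoxy group, or a longer chain such as phenethyl at this position would bear on that question, and none of them stands among the compounds shown.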